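Phenyl in Place of Isobutyl: a Small Step Expected

A few compounds are considered here, and "the series" means these few. Any claim that something is new, unique, unknown or untested is made for them only; others in the source may bear on it.

Of the compounds shown here, three have so far been measured in an ADME assay on BEAS-2B cells (Homo sapiens) for cytotoxicity, read by MTT assay, with a stated time of 72 h; on this read-out lower numbers stand for stronger inhibition of growth and higher numbers for weaker inhibition of growth. Compound 1 `CC(C)COC(=O)Nc1ccc([Se][Se]c2ccc(NC(=O)OCC(C)C)cc2)cc1` gives 42700 nM. Compound 3 `CCCCCCOC(=O)Nc1ccc([Se][Se]c2ccc(NC(=O)OCCCCCC)cc2)cc1` gives 6900 nM. Compound 2 `CC(C)COC(=O)Nc1ccc([Se]C#N)cc1` gives 49500 nM, the highest of the three numbers; it lies within the scatter of compound 1, so those two cannot be told apart, while compound 3 sits clearly lower, beyond the scatter.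

Compound 4 `N#C[Se]c1ccc(NC(=O)Oc2ccccc2)cc1` has not been measured. It differs from compound 2 in a single place: phenyl in place of isobutyl on an oxygen next to a carbonyl group. Going by the values given here, no measured pair of compounds shows this same exchange, so the data give no direct step to lean on. Among the compounds with values here, what can be said is that the only clearly lower number among the three, that of compound 3, comes from a different kind of change, and compound 2 itself lies at the weak end of the set.

Compound 4 is therefore expected to stay close to compound 2, estimated at 38000 nM with a range from 12000 nM to 110000 nM. The expected step of a 1.3-fold lower number from compound 2 to compound 4 (0.11 log units; within the scatter) is small and not beyond the scatter.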

Compound 4, concentration for total growth inhibition: 38200 nM
The estimate for compound 4 lay 1.0-fold (0.00 log units) below the measured number, and the stated range covers the measured number.
By their numbers in this assay, from the lowest: compound 3; then compounds 4, 1 and 2 (each within the scatter of the next).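

Putting phenyl in place of isobutyl on an oxygen next to a carbonyl group gives, in this assay, a 1.3-fold lower number from compound 2 to compound 4 (0.11 log units; within the scatter), so the two compounds cannot be told apart. Going by these compounds alone, this is the first look at a change at this place, and it shows that an open chain can give way to an aromatic ring without a difference beyond the scatter in this read-out. Nothing measured here speaks to the reason for this result.

On these data alone, whether a phenyl carrying an amine or a carboxylic acid on the same oxygen would move the number beyond the scatter remains open. As far as these compounds go, it is also open whether the same exchange would give a similarly small step on the core of compound 1.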